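The source may hold more compounds than are shown below. What is called first, only, known or untested is meant among the compounds shown, and "the series" means these compounds.

Compound 1 `N#C/C(=C\N1CCN(C(=O)c2ccco2)C1=S)C(=O)Nc1ccc(Cl)cc1` gives 6500 nM in a functional assay on MT4 cells (Homo sapiens) for antiproliferative activity, read by MTT assay (on this read-out lower numbers stand for stronger inhibition and higher numbers for weaker inhibition), the lowest of the two numbers recorded so far. Compound 2 `O=C(c1cc(Cl)cc(Cl)c1)N1CCCN(C(=O)c2cc(Cl)cc(Cl)c2)C1=S` follows in this assay with 30000 nM, a gap that lies beyond the usual scatter. Compound 3 `O=C(c1ccccc1Cl)N1CCCN(C(=O)c2ccccc2Cl)C1=S` returns > 100000 nM in this assay, which is a limit of the assay rather than a number. Compound 4 `N#C/C(=C\N1CCN(C(=O)c2ccco2)C1=S)C(N)=O` has not yet been measured; it differs from compound 1 by hydrogen in place of 4-chlorophenyl on an amide-type nitrogen. Going by the values given here, no measured pair shows a step of this kind, so the expectation rests on the change alone. Compound 4 is expected to be a weaker inhibitor, with a step of a 4.6-fold higher number from compound 1 to compound 4 (0.66 log units; beyond the scatter) in this assay. Compound 4 is therefore estimated at 30000 nM in this assay, within a range from 8000 nM to 100000 nM.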

Compound 4, half-maximal inhibitory concentration: 4000 nM
Estimate against measurement, compound 4: 7.5-fold (0.88 log units) above; measured number below the stated range.
By their numbers in this assay, from the lowest: compounds 4 and 1 (each within the scatter of the next); then compound 2. At a limit, above all of these: compound 3.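

Hydrogen in place of 4-chlorophenyl on an amide-type nitrogen gives a 1.6-fold lower number from compound 1 to compound 4 (0.21 log units; within the scatter) in this assay. Going by these compounds alone, the 4-chlorophenyl group is therefore not required at this position for the inhibition read here, which the earlier compounds, with no step among them, could not show. Nothing measured here explains why the number holds. From the compounds shown here alone, whether a methyl or a longer chain such as benzyl on this nitrogen would keep the number remains open. So does whether a carboxylic acid in place of the amide would keep it.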